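Replacing the 4-methylphenyl group in a cytotoxic series

The source may report more compounds than this note shows. Statements on the series, on what has been measured and on what is new or still open speak of the compounds shown alone.

compound 1 `Cc1ccc(C2C(C#N)=C(N)N(c3ccc(S(N)(=O)=O)cc3)C3=C2CCCC3)cc1`: 80%
compound 2 `N#CC1=C(N)N(c2ccc(S(N)(=O)=O)cc2)C2=C(CCCC2)C1/C=C/c1ccccc1`: 90%
compound 3 `COc1ccccc1C1C(C#N)=C(N)N(c2ccc(S(N)(=O)=O)cc2)C2=C1CCCC2`: 50%

All three were tested in a functional assay on Ehrlich cells (Mus musculus) for cytotoxicity, read by trypan blue exclusion, with a stated time of 2 h, tested at 50 ug/mL; a higher number here means a stronger effect of the compound at the concentration tested, a lower number a weaker effect. Compound 1 stands second highest of the three numbers. Compound 2 lies nearest, and a number 10 percentage points higher from compound 1 to compound 2 (within the scatter), so these two cannot be told apart. Compound 3 lies furthest away: a number 30 percentage points lower from compound 1 to compound 3 (beyond the scatter), and likewise a number 40 percentage points lower from compound 2 to compound 3 (beyond the scatter).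

Compound 4 `N#CC1=C(N)N(c2ccc(S(N)(=O)=O)cc2)C2=C(CCCC2)C1c1ccc(Cl)cc1Cl` has not yet been measured. It differs from compound 1 in one place: 2,4-dichlorophenyl in place of 4-methylphenyl on a saturated ring carbon. Among the compounds with values here, the steps that bear on this change are the two that also swap the group on the saturated ring carbon. Moving to 2-phenylethenyl stayed within the scatter, while moving to 2-methoxyphenyl lowered the number by a modest amount. Within the data shown here, no measured step involves a chlorinated ring, so the direction for 2,4-dichlorophenyl cannot be read from the data with confidence. A small downward step is expected in this assay, a number 10 percentage points lower from compound 1 to compound 4 (within the scatter), with a wide range around it. Compound 4 is therefore estimated at 70%, between 45% and 95%.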

Compound 4, a percentage reported as activity, at one concentration (the size of the read-out at that concentration, not a potency): 50%
Compound 4: middle estimate off by 20 percentage points, on the high side, within the range that was stated.
By their numbers in this assay, from the lowest: compounds 3 and 4 (each within the scatter of the next); then compounds 1 and 2 (each within the scatter of the next).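

In this assay, the new group shows that the drop seen with 2-methoxyphenyl is not unique to that group: a number 30 percentage points lower from compound 1 to compound 4 (beyond the scatter), and a number 40 percentage points lower from compound 2 to compound 4 (beyond the scatter). The two lower compounds cannot be told apart, with no change at the digits printed from compound 3 to compound 4 (within the scatter), so 2,4-dichlorophenyl and 2-methoxyphenyl, despite their different substituents, end up at the same level at this saturated ring carbon, while 4-methylphenyl and 2-phenylethenyl both stay higher. Nothing available explains why these groups fall into two levels.

Open, as far as these compounds go, is whether 4-chlorophenyl or 2-chlorophenyl would stay with compound 1 or fall with compound 4, which would show which of the two chlorines goes with the lower number. Also open, from the compounds shown here alone, is how this carbon would respond to a group without an aromatic ring, such as a butyl chain or a carboxylic acid.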